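The compounds below may be only part of what the source reports. "The series", "measured", "known", "first", "only" and "open" are said of these compounds alone.

Measured so far:

- compound 1, `Cc1cccc2sc(N/C(S)=N/[C@H](C)c3cccc4ccccc34)nc12`, which in a functional assay on RBL-2H3 cells (Rattus norvegicus) for inhibition (a lower number here means a stronger inhibitor, a higher number a weaker inhibitor), gives only a limit, > 100000 nM, and not a number
- compound 2, `CCOC(=O)Cc1csc(/N=C(\S)N[C@@H](C)c2cccc3ccccc23)n1`, which in this assay gives 9 nM
- compound 3, `Cc1ccc(N/C(S)=N/[C@H](C)c2cccc3ccccc23)nc1`, which in this assay gives 5 nM

All three share the same core, a thiourea carrying a naphthyl-bearing side chain, and differ only in the aromatic ring attached to the other nitrogen. Compound 3 has the lowest of the two numbers that were obtained, yet compound 2 sits so close to it that the two lie within the usual scatter of repeated measurements and cannot be told apart. Compound 1 stands aside, since its result is only a limit (the limit of > 100000 nM in this assay, at which 1 of the 3 values shown sits).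

Compound 4, `C[C@@H](/N=C(\S)Nc1nccs1)c1cccc2ccccc12`, has not yet been measured. It differs from compound 3 in one place: 1,3-thiazol-2-yl in place of 5-methylpyridin-2-yl on an amine nitrogen. Compound 2 shows that a thiazole ring in this position can go together with a low number, though there the ring carries an ester-bearing chain while in compound 4 it is bare. The expectation is therefore a step of modest size toward a higher number, a 4.0-fold higher number from compound 3 to compound 4 (0.60 log units; beyond the scatter), not certainly beyond the scatter. Compound 4 is estimated at 20 nM, with a likely range from 5 nM to 100 nM.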

Compound 4, half-maximal inhibitory concentration: > 100000 nM
Compound 4: a limit, no number; the forecaster's own chance of this, stated with the estimate: 5%; at least 5000-fold (3.69 log units) between middle value and limit.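

In this assay, putting 1,3-thiazol-2-yl in place of 5-methylpyridin-2-yl on the amine nitrogen gives an at least 20000-fold higher number from compound 3 to compound 4 (4.30 log units; beyond the scatter), so the choice of ring on this nitrogen can separate a strong inhibitor from a compound with no measurable inhibition in this test. From the compounds shown here alone, compound 4 gives a limit and not a number, so the true size of the step stays unknown, and it is not alone in this: the limit of > 100000 nM in this assay, at which 2 of the 4 values shown sit. Compound 2, which carries the same ring with an ester-bearing chain attached to it, gives 9 nM, so a thiazole ring on this nitrogen does not in itself rule out strong inhibition, and what the ring carries appears to matter.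

The compounds shown do not tell whether a small group such as a methyl on the 1,3-thiazol-2-yl ring would be enough to bring inhibition back, or whether a longer chain ending in an ester, a carboxylic acid or an amine is needed. They also leave open how much the methyl contributes in compound 3, which a pyridin-2-yl ring without that methyl would help to show.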